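Amine size and chain length on a shared core

A few compounds are considered here, and "the series" means these few. Any claim that something is new, unique, unknown or untested is made for them only; others in the source may bear on it.

Of the compounds shown here, three on one core have been measured in a functional assay on cells (Homo sapiens) for antiproliferative activity, read by MTT assay, with a stated time of 48 h; on this read-out lower numbers stand for stronger inhibition and higher numbers for weaker inhibition. Compound 1 `CCN(CC)CCn1c(N)c(-c2nc3cc(Cl)ccc3[nH]2)c2nc(C#N)c(C#N)nc21` carries a diethylamino group on a chain; in this assay compound 1 gives only a limit, > 50000 nM. Compound 1 thus sits at the limit of > 50000 nM in this assay, at which 1 of the 3 values shown sits. Compound 2 `CN(C)CCCn1c(N)c(-c2nc3cc(Cl)ccc3[nH]2)c2nc(C#N)c(C#N)nc21` differs by (dimethylamino)methyl in place of diethylamino on a saturated chain carbon, two bonds along the chain from an aromatic nitrogen and in this assay compound 2 gives 28100 nM, so that an at least 1.7-fold lower number from compound 1 to compound 2 (0.25 log units; that floor lies within the scatter). Compound 3 `CCN(CC)CCCn1c(N)c(-c2nc3cc(Cl)ccc3[nH]2)c2nc(C#N)c(C#N)nc21` differs from compound 1 by (diethylamino)methyl in place of diethylamino on a saturated chain carbon, two bonds along the chain from an aromatic nitrogen and in this assay compound 3 gives 23200 nM, so that an at least 2.1-fold lower number from compound 1 to compound 3 (0.33 log units; beyond the scatter). Between the two measured numbers, a 1.2-fold lower number from compound 2 to compound 3 (0.08 log units; within the scatter), which separates compound 2 and compound 3 by nothing that can be ordered.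

Compound 4 `CN(C)CCCCn1c(N)c(-c2nc3cc(Cl)ccc3[nH]2)c2nc(C#N)c(C#N)nc21` has not yet been measured in this assay. It differs from compound 3 by (dimethylamino)methyl in place of diethylamino on a saturated chain carbon, three bonds along the chain from an aromatic nitrogen. For the measured compounds named here, this is the same kind of change as the one from compound 1 to compound 2, but not the same: there the place was two bonds along the chain from an aromatic nitrogen, here it is three bonds along the chain from an aromatic nitrogen. The cores of compound 1 and compound 3 differ in the way already given by (diethylamino)methyl in place of diethylamino on a saturated chain carbon, two bonds along the chain from an aromatic nitrogen. The earlier occurrence gave an at least 1.7-fold lower number from compound 1 to compound 2 (0.25 log units; that floor lies within the scatter), a floor set by a limit rather than a measured size, and the neighbouring change gave a 1.2-fold lower number from compound 2 to compound 3 (0.08 log units; within the scatter). On that basis a step of about a 1.1-fold lower number from compound 3 to compound 4 (0.02 log units; within the scatter) is expected from compound 3 to compound 4 in this assay. Compound 4 is estimated at 22000 nM in this assay, expected between 8000 nM and 50000 nM.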

Compound 4, half-maximal inhibitory concentration: 3280 nM
Compound 4: middle estimate off by 6.7-fold (0.83 log units), on the high side; measured number outside the range, below it.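

In this assay, the change from diethylamino to (dimethylamino)methyl on a saturated chain carbon now stands on two cores, at a different place along the chain on each: the same change on two cores in this assay, an at least 1.7-fold lower number (0.25 log units; that floor lies within the scatter) from compound 1 to compound 2 and a 7.1-fold lower number (0.85 log units; beyond the scatter) from compound 3 to compound 4; the limit leaves it open whether they differ

Only on the core of compound 3 does the change have a measured size, a 7.1-fold lower number from compound 3 to compound 4 (0.85 log units; beyond the scatter), and the new compound also stands apart from the other two, with an 8.6-fold lower number from compound 2 to compound 4 (0.93 log units; beyond the scatter) and an at least 15-fold lower number from compound 1 to compound 4 (1.18 log units; beyond the scatter). This shows that the change can go with a clear step on one core, but not that its size carries over from one core to another, and compound 1 gives no measured size to set against it: the limit of > 50000 nM in this assay, at which 1 of the 4 values shown sits.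

The compounds shown leave open whether the step to compound 4 goes with the 4-(dimethylamino)butyl chain as a whole or with the dimethylamino group alone, a question that a 4-(diethylamino)butyl chain on the shared core would bear on directly. They also leave open how a still longer chain, or a ring amine such as piperidine or morpholine at the chain end, would read in this assay.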